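From Cyclohexyloxy to Cyclohexylamino on the Carbonyl Carbon

The compounds below may be only part of what the source reports. "The series", "measured", "known", "first", "only" and "open" are said of these compounds alone.

Measured so far in a toxicity assay on L02 cells (Homo sapiens) for inhibition, read by CCK-8 assay, with a stated time of 72 h; a lower number here means a stronger inhibitor, a higher number a weaker inhibitor:
- compound 1 `O=C(Cn1cc(CN2C(=O)C(=O)c3c(Cl)ccc(Cl)c32)nn1)OC1CCCCC1`: 40300 nM
- compound 2 `O=C(Cn1cc(CN2C(=O)C(=O)c3c(Cl)ccc(Cl)c32)nn1)Nc1ccccc1`: 24900 nM
- compound 3 `O=C1C(=O)N(Cc2cn(CC(=O)N3CCCCC3)nn2)c2c(Cl)ccc(Cl)c21`: 39300 nM

All three share one core and differ only in the group attached to a carbonyl carbon in the side chain. Compound 1 has the highest number of the three, yet its gap to compound 3 is a 1.0-fold lower number from compound 1 to compound 3 (0.01 log units; within the scatter) and to compound 2 is a 1.6-fold lower number from compound 1 to compound 2 (0.21 log units; within the scatter), so the three stand within the scatter of one another. The unmeasured compound 4 `O=C(Cn1cc(CN2C(=O)C(=O)c3c(Cl)ccc(Cl)c32)nn1)NC1CCCCC1` departs from compound 1 by the following change: cyclohexylamino in place of cyclohexyloxy on a carbonyl carbon.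

The two steps that bear on this are a 1.6-fold lower number from compound 1 to compound 2 (0.21 log units; within the scatter) and a 1.0-fold lower number from compound 1 to compound 3 (0.01 log units; within the scatter), each putting a nitrogen-linked group where the cyclohexyloxy had been, and each within the scatter. The change to compound 4 is of the same kind, so no step beyond the scatter is expected here, perhaps a slightly lower number as seen for compound 2. The estimated step is therefore a 1.2-fold lower number from compound 1 to compound 4 (0.09 log units; within the scatter). For compound 4 the expected value in this assay is 33000 nM, with a range from 15000 nM to 70000 nM.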

Compound 4, half-maximal inhibitory concentration: 83900 nM
The estimate for compound 4 lay 2.5-fold (0.41 log units) below the measured number; the whole stated range lies below it.
By their numbers in this assay, from the lowest: compounds 2, 3 and 1 (each within the scatter of the next); then compound 4.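

In this assay, among the compounds shown here, the groups on this carbonyl carbon had so far stayed within the scatter of one another, but cyclohexylamino gives the first steps beyond it (a 2.1-fold higher number from compound 1 to compound 4 (0.32 log units; beyond the scatter)) and (a 2.1-fold higher number from compound 3 to compound 4 (0.33 log units; beyond the scatter)), making compound 4 the weakest inhibitor of the four. A nitrogen link alone does not set the number, since the group carried on that nitrogen also counts: cyclohexyl in place of phenyl on the amide-type nitrogen gives the largest step here (a 3.4-fold higher number from compound 2 to compound 4 (0.53 log units; beyond the scatter)). No measurement shown explains these differences.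

The compounds shown leave open how other groups on that nitrogen, such as benzyl, cyclopentyl or a short ethyl chain, would compare with phenyl and cyclohexyl. From the compounds shown here alone, it also remains open whether adding a methyl group to the nitrogen of compound 4 would change its number.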